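Amine replacement on the shared core: spiro-diamine variant

The source may report more compounds than this note shows. Statements on the series, on what has been measured and on what is new or still open speak of the compounds shown alone.

Measured compounds:
Compound 1 `CCCN(CCC)c1ccc2cc(NC(=O)CCc3ccc(C(F)(F)F)cc3)ccc2n1` gives 490 nM in an assay on isolated protein for displacement of a labelled ligand from melanin-concentrating hormone receptor 1 (Homo sapiens); on this read-out lower numbers stand for stronger inhibition and higher numbers for weaker inhibition.
Compound 2 `CC(=O)NC1CCN(c2ccc3cc(NC(=O)CCc4ccc(C(F)(F)F)cc4)ccc3n2)C1` gives 5 nM in this assay.
Compound 3 `CC1CCN(c2ccc3cc(NC(=O)CCc4ccc(C(F)(F)F)cc4)ccc3n2)C1` gives 2 nM in this assay.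

Compound 3 stands at the lowest number of the three in this assay; compound 2 is nearest and compound 1 furthest, both steps beyond the scatter. Compound 4 `O=C(CCc1ccc(C(F)(F)F)cc1)Nc1ccc2nc(N3CCC4(CCNC4)C3)ccc2c1` differs from compound 3 on an aromatic carbon: a group of 9 heavy atoms (7 carbon, 2 nitrogen; 2 five-membered non-aromatic rings with 1 hetero atom each) in place of a group of 6 heavy atoms (5 carbon, 1 nitrogen; one five-membered non-aromatic ring with 1 hetero atom), on an aromatic carbon. The steps bearing on this place are a 98-fold lower number from compound 1 to compound 2 (1.99 log units; beyond the scatter) and a 250-fold lower number from compound 1 to compound 3 (2.39 log units; beyond the scatter), both large, with a five-membered non-aromatic ring with 1 hetero atom giving far lower numbers than dipropylamino, and a 2.5-fold lower number from compound 2 to compound 3 (0.40 log units; beyond the scatter), which shows that what sits on that ring shifts the number only modestly. Among the measured compounds shown here, no measured step covers a second five-membered non-aromatic ring or a hydrogen-bond donor here, so the new group is untested. From compound 3 a modest weakening is expected: a 3.0-fold higher number from compound 3 to compound 4 (0.48 log units; beyond the scatter). Compound 4 is estimated at 6 nM, range 1.5 nM to 25 nM.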

Compound 4, half-maximal inhibitory concentration: 0.5 nM
For compound 4 the middle estimate is 12-fold (1.08 log units) above the measured one, and the stated range ends above it.
By their numbers in this assay, from the lowest: compound 4; then compound 3; then compound 2; then compound 1.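

In this assay, the aromatic carbon next to the ring nitrogen accepts the spiro group of 9 heavy atoms, with its 2 five-membered non-aromatic rings and its hydrogen-bond donor, without any loss: the number falls further (a 4.0-fold lower number from compound 3 to compound 4 (0.60 log units; beyond the scatter)) and also against the acetamido-bearing ring (a 10-fold lower number from compound 2 to compound 4 (1.00 log units; beyond the scatter)). The 3-methylpyrrolidin-1-yl group therefore did not mark the floor at this place, and the full replacement of dipropylamino now spans a large step (a 980-fold lower number from compound 1 to compound 4 (2.99 log units; beyond the scatter)). Nothing available accounts for the gain.

The shares of the second ring and of the hydrogen-bond donor remain unseparated, and a methyl or acetyl group on the nitrogen of the second ring would bear on that. Going by these compounds, a piperidine or morpholine at this place also remains open.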